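From isopropyl to methyl on a carbonyl carbon

The compounds below may be only part of what the source reports. "The series", "measured", "known", "first", "only" and "open" are said of these compounds alone.

Values in an ADME assay on HEK293 cells (Homo sapiens) for inhibition, read by MTT assay, with a stated time of 96 h (a lower number here means a stronger inhibitor of growth, a higher number a weaker inhibitor of growth), for the compounds measured so far

- compound 1 `CC(C)C(=O)SCCCCCCNC(=O)c1cc(-c2ccncc2)n[nH]1` gives > 50000 nM as a limit
- compound 2 `C=CCOC(=O)SCCCCCCNC(=O)c1cc(-c2ccncc2)n[nH]1` gives 27500 nM as a number
- compound 3 `CCCCCCCC/C=C\CCCCCCCC(=O)SCCCCCCNC(=O)c1cc(-c2ccncc2)n[nH]1` gives > 50000 nM as a limit

At the limit of > 50000 nM in this assay, at which 2 of the 3 values shown sit, stands compound 1. Compound 4 `CC(=O)SCCCCCCNC(=O)c1cc(-c2ccncc2)n[nH]1` differs from compound 1 by methyl in place of isopropyl on a carbonyl carbon in one place, methyl in place of isopropyl on a carbonyl carbon. The step of an at least 1.8-fold lower number from compound 1 to compound 2 (0.25 log units; that floor lies within the scatter) is the only one measured at that place. The expected step is small and toward a lower number, estimated as an at least 1.4-fold lower number from compound 1 to compound 4 (0.15 log units; that floor lies within the scatter) in this assay for this change. Compound 4 is expected near 35000 nM with an estimated range from 12000 nM to 70000 nM in this growth test.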

Compound 4, concentration for 50% growth inhibition: > 50000 nM
Compound 4 was reported as a limit; the forecaster's own chance of this, stated with the estimate: 40%; middle value at least 1.4-fold (0.15 log units) from the limit.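

In this assay compound 4 gives > 50000 nM, which is a limit and not a number. On this carbonyl carbon, methyl therefore joins isopropyl at the same limit: the limit of > 50000 nM in this assay, at which 3 of the 4 values shown sit. Going by these compounds alone, the step between the two limits cannot be read, and the one readable step is an at least 1.8-fold higher number from compound 2 to compound 4 (0.25 log units; that floor lies within the scatter), so methyl is not clearly set apart from allyloxy.

Still open, from the compounds shown here alone, is whether any group at this place gives a growth inhibition clearly beyond the scatter. An amine or a carboxylic acid on this carbonyl carbon remains untested among the compounds shown here.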